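Aryl sulfone hydroxyamides: moving the methoxy group

The source may report more compounds than this note shows. Statements on the series, on what has been measured and on what is new or still open speak of the compounds shown alone.

Measured so far in a functional assay (Cavia porcellus) with sulfonylurea receptors; K-ATP channels (Homo sapiens) as the target; on this read-out lower numbers stand for stronger inhibition and higher numbers for weaker inhibition:
compound 1 `CC(O)(C(=O)Nc1ccc(S(=O)(=O)c2ccccc2O)cc1)C(F)(F)F` 3090 nM
compound 2 `COc1cccc(S(=O)(=O)c2ccc(NC(=O)C(C)(O)C(F)(F)F)cc2)c1` 16000 nM

Compound 2 stands highest of the two numbers in this assay, and its nearest neighbour is compound 1, which lies a clear step lower (a 5.2-fold higher number from compound 1 to compound 2 (0.71 log units; beyond the scatter)). That step is the only measured one in the series and it concerns a different exchange on the sulfonyl sulfur, so it bears on the present question only in showing that changes of the aryl group on that sulfur can shift the number beyond the scatter.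

Compound 3 `COc1ccc(S(=O)(=O)c2ccc(NC(=O)C(C)(O)C(F)(F)F)cc2)cc1` is not yet measured. Its relation to compound 2 is a change of position only: 4-methoxyphenyl in place of 3-methoxyphenyl on a sulfonyl sulfur. Within the data shown here, no measured pair shows a shift of the methoxy group between ring positions, so there is no direct precedent for the size or direction of this step.

Given that, the expectation for compound 3 in this assay is a number near that of compound 2, with the step of a 1.6-fold lower number from compound 2 to compound 3 (0.20 log units; within the scatter) estimated to lie within or close to the scatter. Compound 3 is estimated at 10000 nM, with a range from 3000 nM to 32000 nM.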

Compound 3, half-maximal inhibitory concentration: > 30000 nM
Compound 3 was reported as a limit; the forecaster's own chance of this, stated with the estimate: 15%; middle value at least 3.0-fold (0.47 log units) away from the limit.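

In this assay compound 3 gives > 30000 nM, which is a limit of the assay and not a number, so the reading supplies only a floor: the limit of > 30000 nM in this assay, at which 1 of the 3 values shown sits.

On these data alone, exchanging 3-methoxyphenyl for 4-methoxyphenyl on the sulfonyl sulfur gives an at least 1.8-fold higher number from compound 2 to compound 3 (0.27 log units; that floor lies within the scatter), so a shift of the methoxy group between these two ring positions has now been tested, but the floor alone does not establish a difference beyond the scatter and the true size of the step remains unknown. Exchanging 2-hydroxyphenyl for 4-methoxyphenyl gives an at least 9.7-fold higher number from compound 1 to compound 3 (0.98 log units; beyond the scatter), and together with a 5.2-fold higher number from compound 1 to compound 2 (0.71 log units; beyond the scatter) this places both methoxyphenyl compounds at higher numbers, beyond the scatter, with no compound shown going against that pattern.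

The compounds shown do not separate the effect of changing hydroxy to methoxy from that of changing the ring position, as both differ together in each step from compound 1. Also open, as far as these compounds go, is how an unsubstituted phenyl group, or a phenyl group carrying an amine or a carboxylic acid, would read at this place on the sulfonyl sulfur.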